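Swapping a Short Ether Chain for a Pyridine Ring

The source may hold more compounds than are shown below. What is called first, only, known or untested is meant among the compounds shown, and "the series" means these compounds.

Compound 1 `COCCOc1ccc2c(c1)CCc1c-2c2c(c3c4ccccc4n(CCO)c13)CNC2=O` gives 40% in an assay on isolated protein for inhibition of mitogen-activated protein kinase kinase kinase 11 (Homo sapiens), tested at 1 uM; a lower number here means less inhibition, a higher number more inhibition at the concentration tested (going by the name of the read-out). Among the compounds with values here, its only measured neighbour, compound 2 `O=C1NCc2c1c1c(c3c2c2ccccc2n3CCO)CCc2cc(OC3CCCC3)ccc2-1`, gives 32%, and the step of a number 8 percentage points lower from compound 1 to compound 2 (within the scatter) stays within the usual scatter, so the two cannot be told apart. Compound 3 `O=C1NCc2c1c1c(c3c2c2ccccc2n3CCO)CCc2cc(OCc3ccccn3)ccc2-1` differs from compound 1 by pyridin-2-yl in place of methoxymethyl on a saturated chain carbon bound to an oxygen on an aromatic ring. Within the data shown here, the one measured step, cyclopentyl in place of 2-methoxyethyl on an oxygen on an aromatic ring, bears on this change and was within the scatter. No step beyond the scatter is therefore expected, and the estimated step is no change at the digits printed from compound 1 to compound 3 (within the scatter). Compound 3 is expected to give 40%, within a range from 25% to 55%.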

Compound 3, a percentage reported as inhibition, at one concentration (the size of the read-out at that concentration, not a potency): 30%
Estimate against measurement, compound 3: 10 percentage points above; the range from low to high includes it.
By their numbers in this assay, from the lowest: compounds 3, 2 and 1 (each within the scatter of the next).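

With (pyridin-2-yl)methyl on the oxygen, this assay shows a number 10 percentage points lower from compound 1 to compound 3 (within the scatter) and a number 2 percentage points lower from compound 2 to compound 3 (within the scatter) and so a group carrying an aromatic ring cannot be told apart here from the open 2-methoxyethyl chain or the cyclopentyl ring. No measurement at hand explains this result. Going by these compounds, whether the ring nitrogen matters stays open, and a plain benzyl group would test that. Also open, on these data alone, is whether an amine, a carboxylic acid or a longer chain at this place would move the number beyond the scatter.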